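Pentyl on selenium: from selenol to pentylseleno

The compounds below may be only part of what the source reports. "The series", "measured", "known", "first", "only" and "open" are said of these compounds alone.

Among the compounds with values here, compound 2 `Nc1nc([SeH])nc2ncccc12` is the only compound here with a number in an ADME assay on BEAS-2B cells (Homo sapiens) for cytotoxicity, read by MTT assay, with a stated time of 72 h; a higher number here means a weaker inhibitor of growth, a lower number a stronger inhibitor of growth: compound 2 gives 5890 nM. Compound 1 `CCCCC[Se]c1nc([Se]CCCCC)c2cccnc2n1` returns only a limit in this assay, where compound 1 gives > 100000 nM. Compound 3 `CCCCC[Se]c1nc(N)c2cccnc2n1` differs from compound 2 by pentyl in place of hydrogen on a selenium. No step between measured compounds is shown, so the size is inferred. The expected step of a 5.1-fold higher number from compound 2 to compound 3 (0.71 log units; beyond the scatter) runs toward weaker growth inhibition, because compound 1 carries pentyl on selenium twice and sits at the limit of > 100000 nM in this assay, at which 1 of the 2 values shown sits. Compound 3 is estimated at 30000 nM, ranging from 8000 nM to 100000 nM, with a real chance of a limit only.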

Compound 3, concentration for 50% growth inhibition: 16300 nM
Compound 3: the middle estimate sits 1.8-fold (0.26 log units) above what was measured, and the stated range covers the measured number.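

Pentyl in place of hydrogen on a selenium gives a 2.8-fold higher number from compound 2 to compound 3 (0.44 log units; beyond the scatter) in this assay, so this change now has a size from a measured pair and not from inference. One nitrogen atom in place of the group carrying the other pentyl on selenium, on an aromatic carbon, gives an at least 6.1-fold lower number from compound 1 to compound 3 (0.78 log units; beyond the scatter). Compound 1 remains a limit and not a number, so this step has no upper end: the limit of > 100000 nM in this assay, at which 1 of the 3 values shown sits.

As far as these compounds go, what a shorter chain such as ethyl, a longer chain such as octyl, or a carboxylic acid at the chain end would do on this selenium stays open.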